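Replacing the 4-(dimethylamino)phenyl group of compound 2

The source may hold more compounds than are shown below. What is called first, only, known or untested is meant among the compounds shown, and "the series" means these compounds.

In a functional assay on OVCAR-3 cells (Homo sapiens) for cytotoxicity, read by sulforhodamine B assay (on this read-out higher numbers stand for weaker inhibition of growth and lower numbers for stronger inhibition of growth), compound 2 `CC1=CC[C@@H]([C@@](C)(O)CCCC(C)(C)NC(=S)N/N=C\c2ccc(N(C)C)cc2)CC1` gives > 100000 nM, which is a limit of the assay and not a number. In this assay compound 1 `CC1=CC[C@@H]([C@@](C)(O)CCCC(C)(C)NC(=S)N/N=C\c2ccc(O)cc2)CC1` gives a measured 17400 nM. Compound 3 `CC1=CC[C@@H]([C@@](C)(O)CCCC(C)(C)NC(=S)N/N=C\c2cccc([N+](=O)[O-])c2)CC1` has 3-nitrophenyl in place of 4-(dimethylamino)phenyl on a carbon with a double bond to nitrogen. Among the measured compounds shown here, one measured step bears on this change: an at least 5.7-fold higher number from compound 1 to compound 2 (0.75 log units; beyond the scatter), which lies beyond the scatter and came with dimethylamino in place of hydroxy on an aromatic carbon. It shows that exchanging the group carried by compound 2 can bring a value into the measurable range, so any measurable value for compound 3 should be a lower number. The expected change is an at least 2.2-fold lower number from compound 2 to compound 3 (0.34 log units; beyond the scatter), towards stronger inhibition of growth, although another limit remains possible. For compound 3 the estimate is 45000 nM, with an expected range of 15000 nM to 100000 nM.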

Compound 3, concentration for total growth inhibition: 40800 nM
For compound 3 the middle estimate is 1.1-fold (0.04 log units) above the measured one; the measured number falls inside the stated range.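

In this assay, 3-nitrophenyl in place of 4-(dimethylamino)phenyl on a carbon with a double bond to nitrogen brings an at least 2.4-fold lower number from compound 2 to compound 3 (0.38 log units; beyond the scatter), so a change of this aromatic group alone can return a measurable value. The size of that step is only a bound, since compound 2 stands at a limit of the assay and not at a number: the limit of > 100000 nM in this assay, at which 1 of the 3 values shown sits. The new group does not match 4-hydroxyphenyl, as 3-nitrophenyl in its place gives a 2.3-fold higher number from compound 1 to compound 3 (0.37 log units; beyond the scatter), which leaves compound 1 with the strongest inhibition of growth among the three compounds.

Compound 3 changes both the substituent and its place on the ring, so the compounds shown cannot separate these two changes. As far as these compounds go, how 4-nitrophenyl or 3-hydroxyphenyl would compare at this position remains open.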